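The source may hold more compounds than are shown below. What is called first, only, known or untested is meant among the compounds shown, and "the series" means these compounds.

Measured compounds:
compound 1, `CNC(=O)c1ccc2noc(-c3ccccc3)c2c1`, 2120 nM
compound 2, `O=C(O)c1ccc2noc(-c3ccc(NC(=O)c4ccccc4)cc3)c2c1`, 580 nM
compound 3, `O=C(O)c1ccc2noc(-c3cccc(C(F)(F)F)c3)c2c1`, 1460 nM

All three were tested in an assay for inhibition of inositol hexakisphosphate kinase 2 (Homo sapiens), read by colorimetric assay, coupled enzyme assay and malachite green, with a stated time of 120 min, in the presence of a further agent that is not named here; a lower number here means a stronger inhibitor, a higher number a weaker inhibitor. Compound 3 gives 1460 nM, the second highest of the three numbers. Its nearest neighbour is compound 1 with 2120 nM, a gap that lies within the usual scatter, so the two cannot be told apart. Compound 2, with 580 nM, stands clearly lower, beyond the scatter.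

Compound 4, `O=C(O)c1ccc2noc(-c3cccc(Oc4ccccc4)c3)c2c1`, has not yet been measured in this assay. It differs from compound 3 in one place: phenoxy in place of trifluoromethyl on an aromatic carbon. Among the measured compounds shown here, no measured pair shows this change, so the expectation rests on what the three values show: compound 2, which carries a larger group, gives the lowest number, 580 nM. On that basis a modest step downward is expected from compound 3 to compound 4, a 1.6-fold lower number from compound 3 to compound 4 (0.21 log units; within the scatter), of a size close to the scatter. Compound 4 is estimated to give 900 nM, within a range from 350 nM to 2500 nM.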

Compound 4, half-maximal inhibitory concentration: 130 nM
Compound 4: the middle estimate sits 6.9-fold (0.84 log units) above what was measured; measured number below the stated range.
By their numbers in this assay, from the lowest: compound 4; then compound 2; then compounds 3 and 1 (each within the scatter of the next).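

Among the compounds shown here, this is the first change at a single place that can be read in this set: in this assay, putting phenoxy in place of trifluoromethyl on this aromatic carbon gives an 11-fold lower number from compound 3 to compound 4 (1.05 log units; beyond the scatter). The position therefore accepts a group with a whole extra aromatic ring, and the inhibitor comes out much stronger with it. No measurement here bears on why the number falls so far.

Going by these compounds, what remains open is whether the added ring or the oxygen linking it matters more; a benzyl group or a methoxy group at this place would help to separate the two. On these data alone, it is also open whether a chlorine atom or an amine on the outer ring of phenoxy would lower the number further or raise it.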